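A few compounds are considered here, and "the series" means these few. Any claim that something is new, unique, unknown or untested is made for them only; others in the source may bear on it.

Compound 3 `CCN(CC)CCNc1nc(-c2ccc(NC(=O)Nc3ccc(Cl)cc3)cc2)nc2c(Cl)c(Cl)sc12` gives 320 nM in a functional assay on NCI-H460 cells (Homo sapiens) for cytotoxicity, read by MTT assay, with a stated time of 72 h (a lower number here means a stronger inhibitor, a higher number a weaker inhibitor), the lowest of the three numbers recorded, though compound 2 `CCN(CC)CCNc1nc(-c2ccc(NC(=O)Nc3ccc(F)cc3)cc2)nc2c(Cl)c(Cl)sc12`, at 500 nM, lies within the scatter of it, and only compound 1 `CN(C)CCNc1nc(-c2ccc(NC(=O)Nc3ccc(Cl)cc3Cl)cc2)nc2c(Cl)c(Cl)sc12`, at 1520 nM, stands clearly higher. Compound 4 `CCN(CC)CCNc1nc(-c2ccc(NC(=O)Nc3ccc(Cl)cc3Cl)cc2)nc2c(Cl)c(Cl)sc12` differs from compound 3 by chloro in place of hydrogen on an aromatic carbon. Among the measured compounds shown here, no measured step shows this exact change. For the measured compounds named here, the one single-site step recorded, a 1.6-fold lower number from compound 2 to compound 3 (0.19 log units; within the scatter), concerns the other halogen and is small. Compound 1 carries the same dichlorophenyl group as compound 4 but a different amine, so its higher number hints, without proof, that the added chloro may raise the number. The step from compound 3 to compound 4 is therefore expected to be a 2.2-fold higher number from compound 3 to compound 4 (0.34 log units; beyond the scatter). Compound 4 is estimated at 700 nM, with a range from 250 nM to 2000 nM.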

Compound 4, half-maximal inhibitory concentration: 1300 nM
Estimate against measurement, compound 4: 1.9-fold (0.27 log units) below, and the stated range covers the measured number.
By their numbers in this assay, from the lowest: compounds 3 and 2 (each within the scatter of the next); then compounds 4 and 1 (each within the scatter of the next).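

The added chloro, on an aromatic carbon ortho to a large group, gives a 4.1-fold higher number from compound 3 to compound 4 (0.61 log units; beyond the scatter) in this assay, so this position does respond to the change. Against the fluoro compound, the 2,4-dichlorophenyl group gives a 2.6-fold higher number from compound 2 to compound 4 (0.41 log units; beyond the scatter) as well. Diethylamino in place of dimethylamino gives only a 1.2-fold lower number from compound 1 to compound 4 (0.07 log units; within the scatter), so the amine change does not separate this pair, and no measurement given here explains either result. From the compounds shown here alone, whether methyl or methoxy at this position would act as chloro does remains open, as does the effect of a cyclic amine such as morpholine on the side chain.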